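The source may hold more compounds than are shown below. What is called first, only, known or untested is meant among the compounds shown, and "the series" means these compounds.

In a functional assay on PC-3 cells (Homo sapiens) for inhibition, read by MTT assay, with a stated time of 24 h (a lower number here means a stronger inhibitor, a higher number a weaker inhibitor), compound 1 `CCCc1cc2ccccc2nc1-c1cc(-c2ccccc2)no1` gives 51300 nM and compound 2 `CCCc1cc2ccccc2nc1-c1cc(-c2ccc(F)cc2)no1` gives 42200 nM; the step from compound 1 to compound 2 is a 1.2-fold lower number from compound 1 to compound 2 (0.08 log units; within the scatter). Compound 3 `CCc1cc2ccccc2nc1-c1cc(-c2ccc(C)cc2)no1` is known in this assay only as a limit, > 100000 nM, and so sits at the limit of > 100000 nM in this assay, at which 1 of the 3 values shown sits. Compound 4 `CCCc1cc2ccccc2nc1-c1cc(-c2ccc(C)cc2)no1` differs from compound 3 by methyl in place of hydrogen on a saturated chain carbon, two bonds along the chain from an aromatic carbon. Among the compounds with values here, no measured step bears on this change: the single measured step, from compound 1 to compound 2, concerns a fluoro on an aromatic carbon and lies within the scatter. The expected step in this assay is therefore an at least 1.4-fold lower number from compound 3 to compound 4 (0.15 log units; that floor lies within the scatter), with no direction claimed beyond the scatter. Compound 4 is accordingly estimated at 70000 nM, between 25000 nM and 200000 nM.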

Compound 4, half-maximal inhibitory concentration: > 100000 nM
Compound 4: no number, only a limit (the forecaster's own chance of this, stated with the estimate: 35%); middle value at least 1.4-fold (0.15 log units) away from the limit.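

In this assay compound 4 is known only as a limit, and the step from compound 3 cannot be read, so methyl on the saturated chain carbon yields no readable change: the limit of > 100000 nM in this assay, at which 2 of the 4 values shown sit.

The new result does bear on the aromatic carbon: methyl in place of fluoro gives an at least 2.3-fold higher number from compound 2 to compound 4 (0.37 log units; beyond the scatter), and methyl in place of hydrogen gives an at least 1.9-fold higher number from compound 1 to compound 4 (0.28 log units; that floor lies within the scatter).

The compounds shown leave open whether a longer chain on the saturated chain carbon, or an amine on the aromatic carbon, would give a readable number.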